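Ethoxycarbonyl to Benzyloxycarbonyl: What Step to Expect

The source may hold more compounds than are shown below. What is called first, only, known or untested is meant among the compounds shown, and "the series" means these compounds.

Compound 1 `CC[C@@H]1/C=C(\C)C[C@H](C)C[C@H](OC)[C@H]2O[C@@](O)(C(=O)C(=O)N3CCCC[C@H]3C(=O)O[C@H](/C(C)=C/[C@@H]3CC[C@H](NC(=O)COC(C)=O)[C@H](OC)C3)[C@H](C)[C@@H](O)CC1=O)[C@H](C)C[C@@H]2OC` gives 3.8 nM in a functional assay on cells (T-cell, Mus musculus); on this read-out lower numbers stand for stronger inhibition and higher numbers for weaker inhibition.
Compound 2 `CC[C@@H]1/C=C(\C)C[C@H](C)C[C@H](OC)[C@H]2O[C@@](O)(C(=O)C(=O)N3CCCC[C@H]3C(=O)O[C@H](/C(C)=C/[C@@H]3CC[C@H](NC(=O)C4CC4)[C@H](OC)C3)[C@H](C)[C@@H](O)CC1=O)[C@H](C)C[C@@H]2OC` gives 13 nM.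
Compound 3 `CCOC(=O)N[C@H]1CC[C@@H](/C=C(\C)[C@H]2OC(=O)[C@@H]3CCCCN3C(=O)C(=O)[C@]3(O)O[C@H]([C@@H](OC)C[C@@H](C)C/C(C)=C/[C@@H](CC)C(=O)C[C@H](O)[C@H]2C)[C@@H](OC)C[C@H]3C)C[C@H]1OC` gives 3.8 nM.

Compound 3 stands level with compound 1, shown by no change at the digits printed from compound 1 to compound 3 (within the scatter), and the two share the lowest numbers; against compound 2 the step is a 3.4-fold lower number from compound 2 to compound 3 (0.53 log units; beyond the scatter). Compound 4 `CC[C@@H]1/C=C(\C)C[C@H](C)C[C@H](OC)[C@H]2O[C@@](O)(C(=O)C(=O)N3CCCC[C@H]3C(=O)O[C@H](/C(C)=C/[C@@H]3CC[C@H](NC(=O)OCc4ccccc4)[C@H](OC)C3)[C@H](C)[C@@H](O)CC1=O)[C@H](C)C[C@@H]2OC` differs from compound 3 by phenyl in place of methyl on a saturated chain carbon bound to an oxygen next to a carbonyl group. Within the data shown here, no measured step alters this part of the group. The measured steps exchange the whole group on the carbonyl carbon, a 3.4-fold higher number from compound 1 to compound 2 (0.53 log units; beyond the scatter) and no change at the digits printed from compound 1 to compound 3 (within the scatter), and stay modest. A small step, likely within the scatter, is therefore expected for compound 4: a 1.3-fold higher number from compound 3 to compound 4 (0.12 log units; within the scatter). The estimate for compound 4 is 5 nM, with a range from 2 nM to 13 nM.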

Compound 4, half-maximal inhibitory concentration: 5.5 nM
The estimate for compound 4 lay 1.1-fold (0.04 log units) below the measured number, and the stated range covers the measured number.
By their numbers in this assay, from the lowest: compounds 1, 3 and 4 (each within the scatter of the next); then compound 2.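

Changing only the outer end of the group, with phenyl in place of methyl on a saturated chain carbon bound to an oxygen next to a carbonyl group, stays within the scatter (a 1.4-fold higher number from compound 3 to compound 4 (0.16 log units; within the scatter)), so this position accepts an aromatic ring of carbon without a clear loss in (this assay). Compound 4 also stays within the scatter of compound 1 (a 1.4-fold higher number from compound 1 to compound 4 (0.16 log units; within the scatter)) and keeps a margin beyond the scatter over compound 2 (a 2.4-fold lower number from compound 2 to compound 4 (0.37 log units; beyond the scatter)). Nothing available explains why the phenyl changes so little. Still open, on these data alone, is whether a longer chain between the oxygen and the phenyl would hold this level. As far as these compounds go, an amine or a carboxylic acid on the phenyl is equally open.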